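The source may hold more compounds than are shown below. What is called first, only, known or untested is meant among the compounds shown, and "the series" means these compounds.

In an assay on membranes from CHO cells for displacement of a labelled ligand from adenosine receptor A1 (Homo sapiens), read by scintillation counting, with a stated time of 60 min, tested at 1 uM (a lower number here means less inhibition, a higher number more inhibition at the concentration tested (going by the name of the read-out)), compound 3 `CCCOC(=O)C1=C(C)N(C)C(=O)NC1c1ccoc1` gives 1%, the lowest of the three numbers recorded. Its nearest neighbour is compound 2 `CCCOC(=O)C1=C(C)N(C)C(=O)NC1c1ccco1` with 3%; the step of a number 2 percentage points lower from compound 2 to compound 3 (within the scatter) lies within the scatter. Furthest away stands compound 1 `CCCOC(=O)C1=C(C)NC(=O)NC1c1cccs1`, which gives 43%, a gap beyond the scatter. Among the compounds with values here, compound 4 `CCCOC(=O)C1=C(C)N(C)C(=O)NC1c1cccs1` is not yet measured; it differs from compound 3 in one place: thiophen-2-yl in place of furan-3-yl on a saturated ring carbon The only measured step, a number 2 percentage points lower from compound 2 to compound 3 (within the scatter), exchanges one furanyl for another on a saturated ring carbon and bears only loosely on the entry of thiophen-2-yl; no measured pair isolates thiophen-2-yl against furan-3-yl. Compound 1 also carries thiophen-2-yl but differs from compound 4 elsewhere as well, so its value is only a hint. Compound 4 is therefore expected to give 6%, from 0% to 20%, an expected step of a number 5 percentage points higher from compound 3 to compound 4 (within the scatter) that stays within the scatter.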

Compound 4, a percentage reported as inhibition, at one concentration (the size of the read-out at that concentration, not a potency): 9%
Compound 4: middle estimate off by 3 percentage points, on the low side; the range from low to high includes it.
By their numbers in this assay, from the lowest: compounds 3, 2 and 4 (each within the scatter of the next); then compound 1.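

In this assay, the ring on the saturated ring carbon matters little: thiophen-2-yl gives a number 8 percentage points higher from compound 3 to compound 4 (within the scatter) and a number 6 percentage points higher from compound 2 to compound 4 (within the scatter) against the two furanyl groups. With thiophen-2-yl held fixed, methyl in place of hydrogen on the amide-type nitrogen in a ring gives a number 34 percentage points lower from compound 1 to compound 4 (beyond the scatter), so the large gap now rests on that single change. No measurement here explains this step. From the compounds shown here alone, whether an ethyl group on that nitrogen would act like methyl remains open. So does whether a phenyl ring on the saturated ring carbon would match the thiophen-2-yl and furanyl groups.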